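A few compounds are considered here, and "the series" means these few. Any claim that something is new, unique, unknown or untested is made for them only; others in the source may bear on it.

Measured compounds:
compound 1 `N#Cc1cc(NC(=O)CN2C(=O)/C(=C/c3ccc(-c4ccc(Cl)cc4)o3)SC2=S)ccc1C(F)(F)F` — > 250000 nM
compound 2 `O=C(CN1C(=O)/C(=C/c2ccc(-c3ccc(Cl)cc3)o2)SC1=S)NCc1ccccc1Cl` — 70000 nM

In a functional assay on REH cells (Homo sapiens) for cytotoxicity, read by MTT assay, with a stated time of 72 h (on this read-out higher numbers stand for weaker inhibition and lower numbers for stronger inhibition), compound 1 reaches only the limit of the assay, > 250000 nM, and no number is known for it; it is one of the values at the limit of > 250000 nM in this assay, at which 1 of the 2 values shown sits. Compound 2 gives 70000 nM in this assay. For the measured compounds named here, the one measured step, an at least 3.5-fold lower number from compound 1 to compound 2 (0.55 log units; beyond the scatter), swaps the same aryl group off the amide-type nitrogen that is changed again in compound 3.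

Compound 3 `O=C(CN1C(=O)/C(=C/c2ccc(-c3ccc(Cl)cc3)o2)SC1=S)Nc1nnn[nH]1` differs from compound 1 by 1H-tetrazol-5-yl in place of 3-cyano-4-(trifluoromethyl)phenyl on an amide-type nitrogen. Going by the values given here, the only measured step that bears on this change is the one from compound 1 to compound 2, which moved the number down by at least a modest amount; the group entering here is smaller and differs in kind from the 2-chlorobenzyl of compound 2, so the expectation is weaker. A lower number than for compound 1 is expected, an at least 1.6-fold lower number from compound 1 to compound 3 (0.22 log units; that floor lies within the scatter), though it may again sit at the limit. For compound 3 the estimate in this assay is 150000 nM, within 50000 nM to 300000 nM.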

Compound 3, half-maximal inhibitory concentration: 50000 nM
Estimate against measurement, compound 3: 3.0-fold (0.48 log units) above; the measured number falls inside the stated range.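

In this assay, 1H-tetrazol-5-yl on the amide-type nitrogen gives an at least 5.0-fold lower number from compound 1 to compound 3 (0.69 log units; beyond the scatter), so a second, very different replacement of 3-cyano-4-(trifluoromethyl)phenyl also yields a measurable number. Compound 1 itself is held only as a limit, so the true size of this step stays unknown: the limit of > 250000 nM in this assay, at which 1 of the 3 values shown sits.

The two replacements cannot be told apart, with a 1.4-fold lower number from compound 2 to compound 3 (0.15 log units; within the scatter), even though 1H-tetrazol-5-yl and 2-chlorobenzyl share little in ring type or heavy-atom make-up. On these data alone, whether a plain phenyl, or a phenyl carrying only the nitrile or only the trifluoromethyl, would also give a measurable number remains open. So does whether a carboxylic acid on a short chain at this nitrogen would read like compound 3, which would test the tetrazole ring itself.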